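The compounds below may be only part of what the source reports. "The series", "measured", "known", "first", "only" and "open" are said of these compounds alone.

Measured compounds:
compound 1 `Cc1ccc(N2CCN(C(=O)C3CCN(C(=O)c4ccc(S(C)(=O)=O)c([N+](=O)[O-])c4)CC3)CC2)cc1` gives > 60000 nM in an assay on isolated protein for inhibition of vitamin D3 receptor (Homo sapiens), read by fluorescence polarization (a higher number here means a weaker inhibitor, a lower number a stronger inhibitor), a limit of the assay and not a number.
compound 2 `CS(=O)(=O)c1ccc(C(=O)N2CCC(C(=O)N3CCC(c4ccccc4)CC3)CC2)cc1[N+](=O)[O-]` gives > 60000 nM in this assay, likewise a limit.

Within the data shown here, compound 1 therefore sits at the limit, as does the only other value shown: the limit of > 60000 nM in this assay, at which 2 of the 2 values shown sit. The step to compound 3 `CS(=O)(=O)c1ccc(C(=O)N2CCC(C(=O)N3CCN(c4ccccc4)CC3)CC2)cc1[N+](=O)[O-]` is hydrogen in place of methyl on an aromatic carbon. With both known values at the limit, no step beyond the scatter in either direction is expected in this assay. For compound 3 the estimate is 60000 nM, range 20000 nM to 200000 nM, most likely reported as a limit again. The expected step is a number no higher from compound 1 to compound 3 (the limit leaves the size open).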

Compound 3, half-maximal inhibitory concentration: > 60000 nM
Compound 3 was reported as a limit; the forecaster's own chance of this, stated with the estimate: 85%; the middle value sits exactly at the limit.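

Among these compounds, no step from compound 1 to compound 3 can be read, as in this assay both compounds sit at a limit of the assay and not at a number. The compounds shown leave open what structure on the shared core would give a measurable value in this assay.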